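Compound 3: trifluoromethyl pyrrolidine after the difluoropiperidine

The source may hold more compounds than are shown below. What is called first, only, known or untested is meant among the compounds shown, and "the series" means these compounds.

Measured so far in a physicochemical assay for solubility, read by HPLC, in phosphate buffer, at pH 6.5; a lower number here means a less soluble compound, a higher number a more soluble compound:
- compound 1 `COC(=O)C1=C(CN2CCNCC2)NC(c2nccs2)=NC1(C)c1ccc(F)cc1` gives 250 ug/mL
- compound 2 `COC(=O)C1=C(CN2CCC(F)(F)CC2)NC(c2nccs2)=NC1(C)c1ccc(F)cc1` gives < 1 ug/mL

Compound 2 stands at < 1 ug/mL as a limit and not a number. Compound 3 `COC(=O)C1=C(CN2CCC(C(F)(F)F)C2)NC(c2nccs2)=NC1(C)c1ccc(F)cc1` carries 3-(trifluoromethyl)pyrrolidin-1-yl in place of 4,4-difluoropiperidin-1-yl on a saturated chain carbon bound to a double-bonded ring carbon. Both groups have no net charge. Among the compounds with values here, the one measured step at this place runs an at least 250-fold lower number from compound 1 to compound 2 (2.39 log units; beyond the scatter) and is large. Compound 3 does not return to piperazin-1-yl, the group whose replacement gave an at least 250-fold lower number from compound 1 to compound 2 (2.39 log units; beyond the scatter) as that large step, so no step beyond the scatter is expected in this assay here. The expected step is a step that the limit leaves unreadable from compound 2 to compound 3 and the reading may again be only a limit. For compound 3 the estimate is 0.8 ug/mL with an expected range of 0.3 ug/mL to 3 ug/mL on this read-out.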

Compound 3, solubility: 13 ug/mL
Compound 3: the middle estimate sits 16-fold (1.21 log units) below what was measured; measured number outside the range, above it.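

In this assay, this position still separates groups when neither carries a net charge: 3-(trifluoromethyl)pyrrolidin-1-yl in place of 4,4-difluoropiperidin-1-yl gives a clear step (an at least 13-fold higher number from compound 2 to compound 3 (1.11 log units; beyond the scatter)). Piperazin-1-yl nevertheless remains clearly ahead of 3-(trifluoromethyl)pyrrolidin-1-yl (a 19-fold lower number from compound 1 to compound 3 (1.28 log units; beyond the scatter)), so the recovery on this saturated chain carbon is only partial. The first of these steps rests on compound 2, whose reading is a limit and not a number: (the limit of < 1 ug/mL in this assay, at which 1 of the 3 values shown sits).

The change from compound 2 to compound 3 alters ring size and fluorine count together, so the compounds shown cannot separate the two. From the compounds shown here alone, how 3-(trifluoromethyl)piperidin-1-yl, morpholin-4-yl or 4-methylpiperazin-1-yl would read at this place remains open.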